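Replacing a Methoxy Ester with a Benzylamide at Fixed Concentration

The source may hold more compounds than are shown below. What is called first, only, known or untested is meant among the compounds shown, and "the series" means these compounds.

Of the compounds shown here, three sharing one core have been tested. Compound 1 `NCCCCCNC1=Nc2ccccc2C(CC(=O)NCc2ccccc2)N1c1ccc(-c2ccccc2)cc1` gives 83.8% in an assay on HEK293 cells for inhibition of Voltage-dependent T-type calcium channel subunit alpha-1G (Homo sapiens), tested at 10 uM; a lower number here means less inhibition, a higher number more inhibition at the concentration tested (going by the name of the read-out); compound 2 `COC(=O)CC1c2ccccc2N=C(NCCCCCN)N1c1ccc(-c2ccccc2)cc1` gives 82.5%; and compound 3 `COC(=O)CC1c2ccccc2N=C(NCCCCCNC(=O)OC(C)(C)C)N1c1ccc(-c2ccccc2)cc1` gives 86.5%, the highest of the three numbers yet within the scatter of both others. The change a number 1.3 percentage points lower from compound 1 to compound 2 (within the scatter) is within the scatter, as is a number 4 percentage points higher from compound 2 to compound 3 (within the scatter). Compound 4 `CC(C)(C)OC(=O)NCCCCCNC1=Nc2ccccc2C(CC(=O)NCc2ccccc2)N1c1ccc(-c2ccccc2)cc1` differs from compound 3 by benzylamino in place of methoxy on a carbonyl carbon, the exact reverse of the change between compound 1 and compound 2, which moved the read-out hardly at all. No step beyond the scatter is therefore expected for compound 4, and its estimated value is 87%, between 78% and 94%, an expected step of a number 0.5 percentage points higher from compound 3 to compound 4 (within the scatter).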

Compound 4, a percentage reported as inhibition, at one concentration (the size of the read-out at that concentration, not a potency): 88.3%
Compound 4: middle estimate off by 1.3 percentage points, on the low side; measured number inside the range.
By their numbers in this assay, from the lowest: compounds 2, 1, 3 and 4 (each within the scatter of the next).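

Benzylamino in place of methoxy on a carbonyl carbon gives a number 1.8 percentage points higher from compound 3 to compound 4 (within the scatter), so this change now stays within the scatter both with and without tert-butoxycarbonyl on the amine nitrogen: the same change on two cores in this assay, a number 1.3 percentage points lower (within the scatter) from compound 1 to compound 2 and a number 1.8 percentage points lower (within the scatter) from compound 4 to compound 3, 0.5 percentage points apart, within the scatter of two such steps. Tert-butoxycarbonyl in place of hydrogen on an amine nitrogen gives a number 4.5 percentage points higher from compound 1 to compound 4 (within the scatter), which repeats on a second core what that change did before: the same change on two cores in this assay, a number 4 percentage points higher (within the scatter) from compound 2 to compound 3 and a number 4.5 percentage points higher (within the scatter) from compound 1 to compound 4, 0.5 percentage points apart, within the scatter of two such steps.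

As far as these compounds go, whether a carboxylic acid or a phenylamino group on this carbonyl carbon would move the read-out remains open. A percentage at one concentration is not a potency, so any differences in potency among these compounds also remain open.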